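The source may hold more compounds than are shown below. What is called first, only, known or untested is meant among the compounds shown, and "the series" means these compounds.

Measured compounds:
compound 1, `CC(C)(C)C#Cc1cc(N(C(=O)[C@H]2CC[C@H](C)CC2)[C@H]2C[C@@H](Oc3cccnc3)C2)c(C(=O)O)s1`: 0.04
compound 2, `C[C@@H](CCOc1cccnc1)N(c1cc(C#CC(C)(C)C)sc1C(=O)O)C(=O)[C@H]1CC[C@H](C)CC1`: 0.02
compound 3, `CC(C)N(c1cc(C#CC(C)(C)C)sc1C(=O)O)C(=O)[C@H]1CC[C@H](Cl)CC1`: 0.14

In an ADME assay for protein binding, using equilibrium dialysis, at pH 7.4, tested at 2 uM (on this read-out lower numbers stand for a smaller free fraction and higher numbers for a larger free fraction), compound 3 gives the highest number of the three; compound 1 lies nearest to it and compound 2 furthest, both gaps beyond the scatter. For the measured compounds named here, the only single-point step among the measured compounds is a 2.0-fold lower number from compound 1 to compound 2 (0.30 log units; within the scatter), which concerns the group on the amide-type nitrogen and stays within the scatter.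

Compound 4, `CC(C)N(C(=O)C1CCCCCC1)c1cc(C#CC(C)(C)C)sc1C(=O)O`, differs from compound 3 in a different place: cycloheptyl in place of 4-chlorocyclohexyl on a carbonyl carbon. Going by the values given here, no measured step touches the group on the carbonyl carbon, so nothing among the measured compounds speaks directly to this change. With two groups of equal heavy-atom count, neither carrying donors or acceptors, the expected step of a 1.2-fold lower number from compound 3 to compound 4 (0.07 log units; within the scatter) is judged to stay within the scatter. Compound 4 is therefore expected to give about 0.12, estimated between 0.06 and 0.25.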

Compound 4, unbound fraction: 0.11
The estimate for compound 4 lay 1.1-fold (0.04 log units) above the measured number, within the range that was stated.
By their numbers in this assay, from the lowest: compounds 2 and 1 (each within the scatter of the next); then compounds 4 and 3 (each within the scatter of the next).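

In this assay, for the compounds shown here, the change on the carbonyl carbon gives a 1.3-fold lower number from compound 3 to compound 4 (0.10 log units; within the scatter), the first reading for this position. Cycloheptyl in place of 4-chlorocyclohexyl, with the chlorine gone and the ring enlarged from six-membered to seven-membered at the same heavy-atom count, leaves the number within the scatter. No measured evidence accounts for this result.

On these data alone, whether an amine, a hydroxyl group or a carboxylic acid on this ring would shift the number remains open. So does whether this step holds with the 3-((pyridin-3-yl)oxy)cyclobutyl group of compound 1 on the amide-type nitrogen.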